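The source may hold more compounds than are shown below. What is called first, only, known or untested is meant among the compounds shown, and "the series" means these compounds.

Compound 1 `COc1cc(OC)c(OC)cc1/C=C/COC(=O)/C=C/c1cccc(Br)c1` and compound 2 `COc1cc(OC)c(OC)cc1/C=C/COC(=O)/C=C/c1ccc(F)cc1` share one core and differ in a single place. In a functional assay on the whole organism (strain Kunming) with Mus musculus as the target, with a stated time of 0.5 h, at a dose of 300 mg/kg by the intraperitoneal route (a higher number here means a weaker effect of the compound at the dose given, a lower number a stronger effect), compound 1 gives 100%. In this assay compound 2 gives 100%. Among the compounds with values here, the one measured step, no change at the digits printed from compound 1 to compound 2 (within the scatter), leaves the two level, so compound 2 stands level with compound 1 in this assay on the numbers so far. Compound 3 `COc1ccc(/C=C/C(=O)OC/C=C/c2cc(OC)c(OC)cc2OC)cc1` is the next variant at the same place: methoxy in place of fluoro on an aromatic carbon. Within the data shown here, the only measured step that bears on this change is no change at the digits printed from compound 1 to compound 2 (within the scatter), a swap on the same six-membered aromatic ring of carbon only, and it stayed within the scatter; a further swap there is therefore expected to move this assay by no more than the scatter, in no set direction. For compound 3 the expected step is a number 3 percentage points lower from compound 2 to compound 3 (within the scatter). Compound 3 is estimated at 97% in this assay, within 80% to 100%.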

Compound 3, a percentage reported as activity, at one dose (the size of the read-out at that dose, not a potency): 100%
The estimate for compound 3 lay 3 percentage points below the measured number; the range from low to high includes it.
By their numbers in this assay, from the lowest: compounds 1, 2 and 3 (each within the scatter of the next).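

Methoxy in place of fluoro on an aromatic carbon, para to a large group, gives no change at the digits printed from compound 2 to compound 3 (within the scatter) in this assay, so a group that adds a hydrogen-bond acceptor at this place leaves the read-out flat, as the halogen swap did. Read against the bromo compound, 4-methoxyphenyl in place of 3-bromophenyl gives no change at the digits printed from compound 1 to compound 3 (within the scatter), so a non-halogen group now sits level with both halogen-bearing variants. No measurement is available that would explain this flat read-out.

On these data alone, whether an amine or a carboxylic acid on this aromatic carbon, or a longer chain in the shared core, would shift the number remains open. As far as these compounds go, these are read-outs at a single dose, so whether compounds 1, 2 and 3 would show a stronger or weaker effect at any other dose also remains open.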